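The compounds below may be only part of what the source reports. "The series", "measured", "known", "first", "only" and "open" are said of these compounds alone.

In a functional assay on HCT-116 cells (Homo sapiens), read by MTT assay, with a stated time of 72 h (a lower number here means a stronger inhibitor, a higher number a weaker inhibitor), compound 3, `Cc1nc(N)c2c(-c3ccccc3)cn([C@@H]3O[C@H](CO)[C@@H](O)[C@H]3O)c2n1`, gives > 20000 nM, which is a limit of the assay and not a number. Compound 1, `Cc1nc(N)c2c(-c3ccco3)cn([C@@H]3O[C@H](CO)[C@@H](O)[C@H]3O)c2n1`, gives > 20000 nM, also a limit. Compound 2, `Cc1nc(N)c2c(-c3ccsc3)cn([C@@H]3O[C@H](CO)[C@@H](O)[C@H]3O)c2n1`, gives > 20000 nM, again a limit. All the measured values therefore sit together: the limit of > 20000 nM in this assay, at which 3 of the 3 values shown sit.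

Compound 4, `Cc1nc(N)c2c(-c3cc4ccccc4o3)cn([C@@H]3O[C@H](CO)[C@@H](O)[C@H]3O)c2n1`, carries 1-benzofuran-2-yl in place of phenyl on an aromatic carbon. The closest measured changes swap one aromatic group for another at this same carbon, and none has a readable size. They are a step that the two limits leave unreadable from compound 1 to compound 3, a step that the two limits leave unreadable from compound 2 to compound 3 and a step that the two limits leave unreadable from compound 1 to compound 2.

These steps offer no measured gain to build on, so no step beyond the scatter is expected, and compound 4 will most likely stop at the same limit. The estimated step is a number no higher from compound 3 to compound 4 (the limit leaves the size open). For compound 4 the expected value is 20000 nM, with an estimated range from 8000 nM to 40000 nM.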

Compound 4, half-maximal inhibitory concentration: 13100 nM
Beside the measured number, compound 4's estimate is 1.5-fold (0.18 log units) above it; low and high end bracket the measured number.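

In this assay, among the compounds shown here, compound 4, with 1-benzofuran-2-yl on this aromatic carbon, is the first compound here to give a number and not a limit. Against the other aromatic groups, the change gives an at least 1.5-fold lower number from compound 3 to compound 4 (0.18 log units; that floor lies within the scatter) and an at least 1.5-fold lower number from compound 2 to compound 4 (0.18 log units; that floor lies within the scatter) and an at least 1.5-fold lower number from compound 1 to compound 4 (0.18 log units; that floor lies within the scatter); each of these steps has only a floor, while the steps among compound 1, compound 2 and compound 3 cannot be read. Whether the added ring truly matters therefore stays unsettled, and most of the series remains at the limit: the limit of > 20000 nM in this assay, at which 3 of the 4 values shown sit.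

The compounds shown leave open whether naphthalen-2-yl or 1-benzothiophen-2-yl on this carbon would move the number beyond the scatter. They also leave open what an amine or a carboxylic acid on the 1-benzofuran-2-yl group would do.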